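Urea aryl swaps in a quinazoline series

The compounds below may be only part of what the source reports. "The series", "measured", "known", "first", "only" and "open" are said of these compounds alone.

Compound 3 `COc1cc2ncnc(NCc3cccc(NC(=O)Nc4ccc(F)cc4)c3)c2cc1OC` gives the highest number of the three in a functional assay on HepG2 cells (Homo sapiens) for antiproliferative activity, read by MTT assay (a lower number here means a stronger inhibitor, a higher number a weaker inhibitor), with 36600 nM; compound 1 `COc1ccccc1NC(=O)Nc1cccc(CNc2ncnc3cc(OC)c(OC)cc23)c1` gives 27200 nM and compound 2 `COc1cc2ncnc(NCc3cccc(NC(=O)Nc4ccccc4F)c3)c2cc1OC` gives 24900 nM, both within the scatter of compound 3. Compound 4 `COc1cc2ncnc(NCc3cccc(NC(=O)Nc4ccccc4Cl)c3)c2cc1OC` differs from compound 3 by 2-chlorophenyl in place of 4-fluorophenyl on an amide-type nitrogen. Within the data shown here, the steps that bear on this change are a 1.5-fold higher number from compound 2 to compound 3 (0.17 log units; within the scatter), a 1.1-fold lower number from compound 1 to compound 2 (0.04 log units; within the scatter) and a 1.3-fold higher number from compound 1 to compound 3 (0.13 log units; within the scatter), all within the scatter, so no step beyond the scatter is expected in this assay for the move to a 2-chlorophenyl group. The expected step is a 1.3-fold lower number from compound 3 to compound 4 (0.12 log units; within the scatter). Compound 4 is therefore estimated at 28000 nM in this assay, with a range from 12000 nM to 65000 nM.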

Compound 4, half-maximal inhibitory concentration: 25500 nM
Compound 4: the middle estimate sits 1.1-fold (0.04 log units) above what was measured; the range from low to high includes it.
By their numbers in this assay, from the lowest: compounds 2, 4, 1 and 3 (each within the scatter of the next).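

In this assay, 2-chlorophenyl on the amide-type nitrogen leaves the number within the scatter of all three earlier compounds, with a 1.4-fold lower number from compound 3 to compound 4 (0.16 log units; within the scatter) and a 1.0-fold higher number from compound 2 to compound 4 (0.01 log units; within the scatter) and a 1.1-fold lower number from compound 1 to compound 4 (0.03 log units; within the scatter). Chloro thus joins fluoro and methoxy on the aromatic carbon without separating from either, and the four aryl groups shown cannot be told apart in this assay. No available evidence accounts for this flat response.

On these data alone, whether any change at this place moves the number beyond the scatter remains open. A phenyl carrying an amine or a carboxylic acid, or a cyclohexyl group in place of the phenyl, would test that.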